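This account rests on a few compounds, and the source may have more. Where it says the series, first, only, none or still open, it means among the compounds named here.

Compound 1, `Nc1cccc(/C=C2\SC(=O)N(Cc3ccccc3)C2=O)c1`, in a functional assay on FM3A cells (Mus musculus) for cytotoxicity, read by cell counting, with a stated time of 2 days; on this read-out lower numbers stand for stronger inhibition and higher numbers for weaker inhibition: > 250000 nM, a limit of the assay.
Compound 2, `Nc1ccc(/C=C2\SC(=O)N(Cc3ccc(Cl)cc3)C2=O)cc1`, in this assay: 60000 nM.

Compound 2 stands alone as the only number shown. The other entry is the limit belonging to compound 1, (the limit of > 250000 nM in this assay, at which 1 of the 2 values shown sits). Compound 3, `Nc1ccc(/C=C2\SC(=O)N(Cc3ccccc3)C2=O)cc1`, differs from compound 2 by hydrogen in place of chloro on an aromatic carbon. Within the data shown here, no step between measured compounds is available here, so only a modest step toward weaker inhibition, or none beyond the usual scatter, is expected in this assay. Compound 3 is accordingly expected near 100000 nM, within 40000 nM to 250000 nM. The expected step of a 1.7-fold higher number from compound 2 to compound 3 (0.22 log units; within the scatter) is small.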

Compound 3, half-maximal inhibitory concentration: 24000 nM
Beside the measured number, compound 3's estimate is 4.2-fold (0.62 log units) above it, and the stated range ends above it.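

In this assay, hydrogen in place of chloro on the aromatic carbon, 4-chlorophenyl to phenyl, gives a 2.5-fold lower number from compound 2 to compound 3 (0.40 log units; beyond the scatter), so the chloro is not needed for this cytotoxicity and its loss does not weaken the read-out. With the phenyl kept, 4-aminophenyl in place of 3-aminophenyl gives an at least 10-fold lower number from compound 1 to compound 3 (1.01 log units; beyond the scatter), showing that the place of the amine counts for more than the chloro. Compound 1 stands at a limit of the assay, not at a number: the limit of > 250000 nM in this assay, at which 1 of the 3 values shown sits.

From the compounds shown here alone, whether fluoro or methoxy at the chloro's place would behave like hydrogen or like chloro stays open. So does the effect of a hydroxyl in place of the amine.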